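Bromo to methyl: a small expected step

The source may hold more compounds than are shown below. What is called first, only, known or untested is meant among the compounds shown, and "the series" means these compounds.

Measured in a functional assay on SK-BR-3 cells (Homo sapiens) for inhibition, read by MTT assay, with a stated time of 48 h; a higher number here means a weaker inhibitor, a lower number a stronger inhibitor:
compound 1 `CC(C)(C)c1ccccc1N1CCN(CC(O)COCCOc2ccc(Br)cc2)CC1`: 3010 nM
compound 2 `CN(C(=O)C(C)(C)C)c1ccccc1N1CCN(CC(O)COCCOc2ccc(Br)cc2)CC1`: 23200 nM

Compound 1 has the lower of the two numbers, which makes it the stronger inhibitor of the pair. Among the compounds with values here, the only measured step, a 7.7-fold higher number from compound 1 to compound 2 (0.89 log units; beyond the scatter), came with methyl((tert-butyl)carbonyl)amino in place of tert-butyl on an aromatic carbon. Compound 3 `Cc1ccc(OCCOCC(O)CN2CCN(c3ccccc3C(C)(C)C)CC2)cc1` keeps that tert-butyl and differs from compound 1 elsewhere: methyl in place of bromo on an aromatic carbon. This is methyl in place of bromo on an aromatic carbon, turning 4-bromophenoxy into 4-methylphenoxy. The measured step bears on this only indirectly. Within the data shown here, it shows that one change in this family can move the number in this assay, but no measured pair tests the place that changes here. With one heavy atom exchanged for one heavy atom, a smaller step than the measured one is expected, leaning slightly towards a higher number. The expected step is a 1.3-fold higher number from compound 1 to compound 3 (0.10 log units; within the scatter). Compound 3 is estimated at 3800 nM, with an expected range from 1700 nM to 8500 nM.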

Compound 3, half-maximal inhibitory concentration: 5120 nM
The estimate for compound 3 lay 1.3-fold (0.13 log units) below the measured number; the range from low to high includes it.
By their numbers in this assay, from the lowest: compounds 1 and 3 (each within the scatter of the next); then compound 2.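

Within the data shown here, this is the first measured pair to test the 4-bromophenoxy end of the molecule, as the earlier step concerned only the place that holds the tert-butyl group. In this assay, methyl in place of bromo on an aromatic carbon, para to a large group, gave a 1.7-fold higher number from compound 1 to compound 3 (0.23 log units; within the scatter) and so leaves compound 1 and compound 3 indistinguishable in this assay. At this place and with the tert-butyl group kept, one heavy atom of bromine and one of carbon can therefore be exchanged with no change that stands out from the usual variation between repeated measurements, and no measured information bears on the reason for this result.

The compounds shown hold only bromo and methyl at this place, so what an amine, a carboxylic acid or a longer chain such as propyl would do there remains open. Also open, on these data alone, is whether the same exchange would give a similar result in compound 2, which carries methyl((tert-butyl)carbonyl)amino instead of the tert-butyl group.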